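This account rests on a few compounds, and the source may have more. Where it says the series, first, only, none or still open, it means among the compounds named here.

Values in a functional assay on MCF7 cells (Homo sapiens) for cytotoxicity, in the presence of a further agent that is not named here; a lower number here means that less compound is needed, a higher number that more compound is needed for the effect:
- compound 1 `CCCCCCCO[C@@H]1[C@@H](O)[C@@H](OCc2ccccc2)O[C@H](CC(C)C)[C@H]1OC`: 7 ug/mL
- compound 2 `CCCCCCCO[C@@H]1[C@@H](O)[C@@H](OCc2ccccc2)O[C@H](CO)[C@H]1O`: > 20 ug/mL
- compound 3 `CCCCCCCO[C@@H]1[C@@H](OCc2ccccc2)[C@@H](OCc2ccccc2)O[C@H](CO)[C@H]1OCc1ccc(OC)cc1`: 3 ug/mL

Compound 2 reaches only a limit of the assay, > 20 ug/mL. The gap between the two actual numbers lies beyond the scatter. Compound 1 holds the higher at 7 ug/mL, and compound 3 the lower at 3 ug/mL.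

Compound 4 `CCCCCCCO[C@@H]1[C@@H](O)[C@@H](OCc2ccccc2)O[C@H](CC(C)C)[C@H]1OCc1ccc(OC)cc1` departs from compound 1 by 4-methoxyphenyl in place of hydrogen on a saturated chain carbon bound to an oxygen on a saturated carbon, so that methoxy becomes (4-methoxybenzyl)oxy. For the measured compounds named here, no measured pair isolates this change. Going by the values given here, the only guide is compound 3, which also carries (4-methoxybenzyl)oxy and gives 3 ug/mL, though it differs elsewhere too. In this assay a small move toward a lower number is therefore expected, the estimated step being a 1.8-fold lower number from compound 1 to compound 4 (0.24 log units; within the scatter). For compound 4 the expected value is 4 ug/mL, within a range of 2 ug/mL to 9 ug/mL.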

Compound 4, half-maximal effective concentration: 4 ug/mL
For compound 4 middle estimate and measured number coincide at the digits printed; the range from low to high includes it.
By their numbers in this assay, from the lowest: compounds 3, 4 and 1 (each within the scatter of the next, the first and the last beyond it). At a limit, above all of these: compound 2.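

For the compounds shown here, exchanging methoxy for (4-methoxybenzyl)oxy gives the first comparison in this set that differs in one place: in this assay the change amounts to a 1.8-fold lower number from compound 1 to compound 4 (0.24 log units; within the scatter). This position therefore carries 4-methoxyphenyl in place of hydrogen with no difference that the assay can separate from the scatter. Nothing measured here gives a cause for this result. Going by these compounds, whether an amine or a carboxylic acid on the same chain carbon would behave alike stays open. So does the effect of a longer chain in place of the 4-methoxybenzyl group.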